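Moving the methyl on the spiro-fused aryl ring

The compounds below may be only part of what the source reports. "The series", "measured", "known", "first", "only" and "open" are said of these compounds alone.

Compound 2 `CC1=NN(c2ccccc2)C(=O)C12C=CC(=O)C=C2c1ccc(C)cc1` gives 27100 nM in a functional assay on HCT-116 cells (Homo sapiens) for antiproliferative activity, read by CCK-8 assay, with a stated time of 72 h; on this read-out higher numbers stand for weaker inhibition and lower numbers for stronger inhibition. Compound 1 `CC1=NN(c2ccccc2)C(=O)C12C=CC(=O)C=C2c1cccc(C)c1` reaches only the assay limit of > 100000 nM in this assay. The change between them, (3-methylphenyl in place of 4-methylphenyl on a double-bonded ring carbon), produced an at least 3.6-fold higher number from compound 2 to compound 1 (0.56 log units; beyond the scatter); that step carries an at least figure because of the limit of > 100000 nM in this assay, at which 1 of the 3 values shown sits. Compound 3 `CC1=NN(c2ccc(Br)cc2)C(=O)C12C=CC(=O)C=C2c1ccc(C)cc1` differs from compound 2 in its core by bromo in place of hydrogen on an aromatic carbon, a change that brought a 2.6-fold lower number from compound 2 to compound 3 (0.41 log units; beyond the scatter), and compound 3 stands at 10600 nM in this assay. Compound 4 `CC1=NN(c2ccc(Br)cc2)C(=O)C12C=CC(=O)C=C2c1cccc(C)c1` awaits measurement; it differs from compound 3 by 3-methylphenyl in place of 4-methylphenyl on a double-bonded ring carbon, the same change made from compound 2 to compound 1. Since that change earlier gave an at least 3.6-fold higher number from compound 2 to compound 1 (0.56 log units; beyond the scatter), a weakening of comparable size is expected here, namely a 4.7-fold higher number from compound 3 to compound 4 (0.67 log units; beyond the scatter). Compound 4 is accordingly estimated at 50000 nM in this assay, likely between 20000 nM and 150000 nM.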

Compound 4, half-maximal inhibitory concentration: > 100000 nM
Compound 4 ended at the assay's limit; the forecaster's own chance of this, stated with the estimate: 35%; at least 2.0-fold (0.30 log units) between middle value and limit.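

Changing 4-methylphenyl to 3-methylphenyl also weakened activity on the bromo-bearing core in this assay, with an at least 9.4-fold higher number from compound 3 to compound 4 (0.97 log units; beyond the scatter), so the direction of the change held on both cores shown. The size of the effect cannot be compared between the two cores: the same change on two cores in this assay, an at least 3.6-fold higher number (0.56 log units; beyond the scatter) from compound 2 to compound 1 and an at least 9.4-fold higher number (0.97 log units; beyond the scatter) from compound 3 to compound 4; the limit leaves it open whether they differ. The step from compound 1 to compound 4 cannot be read, so these compounds do not show what bromo does when 3-methylphenyl is present: the limit of > 100000 nM in this assay, at which 2 of the 4 values shown sit.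

The compounds shown leave open how a plain phenyl or an aminophenyl would behave on the double-bonded ring carbon. As far as these compounds go, it also remains open whether a chloro or a carboxylic acid in place of the bromo would keep the gain seen with 4-methylphenyl.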